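This account rests on a few compounds, and the source may have more. Where it says the series, first, only, none or still open, it means among the compounds named here.

Compound 1, `O=C1NCCc2nc(C#Cc3ccccc3)sc21`: in an assay on HEK293 cells for negative allosteric modulation of metabotropic glutamate receptor 5 (Homo sapiens), read by FLIPR, with a stated time of 1 h (on this read-out lower numbers stand for stronger inhibition and higher numbers for weaker inhibition), compound 1 gives > 10000 nM, which is a limit of the assay rather than a number.
Compound 2, `Cc1cccc(C#Cc2nc3c(s2)C(=O)NCC3)c1`: in this assay compound 2 gives > 10000 nM, again a limit.
Compound 3, `C(#Cc1nc2c(s1)CN(C1CCCCC1)CC2)c1ccccc1`: in this assay compound 3 gives > 10000 nM, also a limit.

Compound 3 thus stands at the limit of > 10000 nM in this assay, at which 3 of the 3 values shown sit, so nothing sets it apart from the other two. Compound 4 is `COC1CC(C(=O)N2CCc3nc(C#Cc4ccccc4)sc3C2)C1`; it differs from compound 3 by (3-methoxycyclobutyl)carbonyl in place of cyclohexyl on an amine nitrogen in a ring. For the measured compounds named here, no measured step bears on this exchange: the single step recorded, a step that the two limits leave unreadable from compound 1 to compound 2, changes another part of the molecule and cannot be read, as both of its ends are limits. No direction can be drawn from the data. Compound 4 is therefore expected to give roughly 6000 nM in this assay, somewhere between 1000 nM and 30000 nM, with a real chance that only a limit is reported again. That expectation corresponds to a step of an at least 1.6-fold lower number from compound 3 to compound 4 (0.22 log units; that floor lies within the scatter).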

Compound 4, half-maximal inhibitory concentration: > 10000 nM
Compound 4: no number, only a limit; the forecaster's own chance of this, stated with the estimate: 60%; middle value at least 1.6-fold (0.22 log units) from the limit.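

For the compounds shown here, compound 3 and compound 4 both give only a limit rather than a number, so no step between them can be read. The compounds shown leave open whether (3-methoxycyclobutyl)carbonyl in place of cyclohexyl changes inhibition at all.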